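The compounds below may be only part of what the source reports. "The series", "measured", "known", "first", "only" and "open" are said of these compounds alone.

Compound 1 `Cc1ccc(-c2noc(CCCCCCC(=O)NO)n2)cc1` - 5810 nM
Compound 2 `O=C(CCCCCCc1nc(-c2ccccc2Cl)no1)NO` - 8870 nM

Both values come from a functional assay on A549 cells (Homo sapiens) for antiproliferative activity, read by MTT assay, with a stated time of 72 h; a lower number here means a stronger inhibitor, a higher number a weaker inhibitor. Compound 2 stands at 8870 nM, within the scatter of compound 1, so the two cannot be ordered. Within the data shown here, the only measured step is a 1.5-fold higher number from compound 1 to compound 2 (0.18 log units; within the scatter), an exchange of one carbon-only aryl group for another at the same place on the shared core.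

Compound 3 `O=C(CCCCCCc1nc(-c2cccnc2)no1)NO` carries pyridin-3-yl in place of 2-chlorophenyl on an aromatic carbon. No group with a ring hetero atom has yet been measured at this place, so this single small step is a thin guide. No step beyond the scatter is therefore expected in this assay, and no direction is firmly indicated. The expected change is a 1.4-fold lower number from compound 2 to compound 3 (0.14 log units; within the scatter). For compound 3 the estimated value is 6500 nM, with an expected range of 2500 nM to 16000 nM.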

Compound 3, half-maximal inhibitory concentration: 5340 nM
Compound 3: the middle estimate sits 1.2-fold (0.09 log units) above what was measured; low and high end bracket the measured number.
By their numbers in this assay, from the lowest: compounds 3, 1 and 2 (each within the scatter of the next).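

In this assay, among these compounds, the first group with a ring hetero atom at this place, pyridin-3-yl, gives a 1.7-fold lower number from compound 2 to compound 3 (0.22 log units; within the scatter) and a 1.1-fold lower number from compound 1 to compound 3 (0.04 log units; within the scatter). Replacing either carbon-only aromatic ring with a six-membered aromatic ring holding one hetero atom and one hydrogen-bond acceptor therefore leaves all three compounds within the scatter of one another, so the change has no readable effect on this aromatic carbon in the set shown. No measurement bears on why these numbers stay so close.

The compounds shown leave open whether any group on this aromatic carbon can produce a step beyond the scatter. An amine or a carboxylic acid on the aromatic ring, or a longer chain on the shared core, remains an open case.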